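From Fluorophenyl to Naphthyl on the Shared Core

A few compounds are considered here, and "the series" means these few. Any claim that something is new, unique, unknown or untested is made for them only; others in the source may bear on it.

Three compounds have been measured in a functional assay, tested at 400 ug/mL; on this read-out higher numbers stand for a stronger effect at the one concentration tested and lower numbers for a weaker effect:

compound 1 `CN(C)c1ccc(C2C(C#N)=C(N)OC(c3c[nH]c4ccccc34)=C2C#N)cc1` gives 26.7%
compound 2 `Cc1ccc(C2C(C#N)=C(N)OC(c3c[nH]c4ccccc34)=C2C#N)cc1` gives 8.5%
compound 3 `N#CC1=C(N)OC(c2c[nH]c3ccccc23)=C(C#N)C1c1ccc(F)cc1` gives 26.7%

Compound 3 stands level with compound 1 at the digits printed, and the two together hold the highest numbers of the three in this assay. Within the data shown here, the only step beyond the scatter runs from compound 2: a number 18.2 percentage points higher from compound 2 to compound 3 (beyond the scatter), while no change at the digits printed from compound 1 to compound 3 (within the scatter). Both measured steps exchange one small group for another on an aromatic carbon of the ring that sits on the saturated ring carbon.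

Compound 4 `N#CC1=C(N)OC(c2c[nH]c3ccccc23)=C(C#N)C1c1cccc2ccccc12` changes that ring itself: naphthalen-1-yl in place of 4-fluorophenyl on a saturated ring carbon. Among the measured compounds shown here, no measured step replaces the whole ring, so neither step bears on this change directly; the two that touch the same region were of modest size or within the scatter. A change in this assay beyond the scatter in either direction cannot be ruled out, but nothing here points one way, so the expectation is a number 1.7 percentage points lower from compound 3 to compound 4 (within the scatter), a step within the scatter. Compound 4 is therefore estimated at 25%, with a range from 8% to 45%.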

Compound 4, a percentage reported as activity, at one concentration (the size of the read-out at that concentration, not a potency): 10.4%
Compound 4: the middle estimate sits 14.6 percentage points above what was measured; the range from low to high includes it.
By their numbers in this assay, from the lowest: compounds 2 and 4 (each within the scatter of the next); then compounds 1 and 3 (each within the scatter of the next).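

In this assay, the saturated ring carbon proves sensitive to an exchange of the whole ring and not only of the small group on it, with a number 16.3 percentage points lower from compound 3 to compound 4 (beyond the scatter) and a number 16.3 percentage points lower from compound 1 to compound 4 (beyond the scatter). Naphthalen-1-yl nevertheless does not set a new level of its own: with a number 1.9 percentage points higher from compound 2 to compound 4 (within the scatter), it falls in with 4-methylphenyl, so the four compounds form two levels, 4-fluorophenyl and 4-(dimethylamino)phenyl in one and 4-methylphenyl and naphthalen-1-yl in the other. Nothing available gives a reason for this split into two levels.

The compounds shown leave open whether the outcome for naphthalen-1-yl depends on the second ring as such or on the way it is attached, a question that naphthalen-2-yl on the same carbon would address. They also leave open which of the two levels would take in a phenyl ring carrying a methoxy group, a chloro group or a carboxylic acid, and so whether the split holds beyond these four compounds.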